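Propargyloxy swap on the cinnamamide of compound 2

A few compounds are considered here, and "the series" means these few. Any claim that something is new, unique, unknown or untested is made for them only; others in the source may bear on it.

Two compounds of the series have numbers in a functional assay on B16 cells (Mus musculus) for cytotoxicity, read by MTT assay, with a stated time of 72 h; on this read-out higher numbers stand for weaker inhibition and lower numbers for stronger inhibition. Compound 1, `COc1cccc(/C=C/C(=O)Nc2cc(OC)c(OC)c(OC)c2)c1`, gives 8500 nM. Compound 2, `COc1ccc(/C=C/C(=O)Nc2cc(C(=O)c3cc(OC)c(OC)c(OC)c3)cc(OC)c2OC)cc1OC`, gives 1300 nM. Among the measured compounds shown here, compound 2 stands lowest of the two; its only neighbour is compound 1, whose number is higher by a margin beyond the scatter. For the measured compounds named here, the two compounds differ in more than one place, so their values show only that compound 2 sits well below compound 1 in this assay, not which part of the difference carries that gap.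

Compound 3, `C#CCOc1cccc(/C=C/C(=O)Nc2cc(C(=O)c3cc(OC)c(OC)c(OC)c3)cc(OC)c2OC)c1`, is not yet measured. It differs from compound 2 in one place: 3-(propargyloxy)phenyl in place of 3,4-dimethoxyphenyl on a double-bonded chain carbon bound to a double-bonded chain carbon. Going by the values given here, no measured pair isolates this change, so the size of the step can only be judged loosely, and no direction is firmly supported. For compound 3 the expected step is a 1.5-fold higher number from compound 2 to compound 3 (0.19 log units; within the scatter), a mild rise that may stay within the scatter. For compound 3 in this assay an estimate of 2000 nM is offered, with a range from 700 nM to 6000 nM.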

Compound 3, half-maximal inhibitory concentration: 5100 nM
The estimate for compound 3 lay 2.6-fold (0.41 log units) below the measured number, and the stated range covers the measured number.
By their numbers in this assay, from the lowest: compound 2; then compounds 3 and 1 (each within the scatter of the next).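

Among the compounds shown here, the first single-place comparison falls on a double-bonded chain carbon bound to a double-bonded chain carbon: in this assay, 3-(propargyloxy)phenyl in place of 3,4-dimethoxyphenyl gives a 3.9-fold higher number from compound 2 to compound 3 (0.59 log units; beyond the scatter), so the number responds to the group held at this position. The step comes with no change in the heavy-atom count, since both groups hold 10 heavy atoms and one six-membered aromatic ring of carbon only; the counted differences are 1 hydrogen-bond acceptor against 2 and a triple bond outside aromatic rings. No independent measurement bears on what lies behind the step.

Which part of the swap carries the step stays open, as the triple bond and the change in oxygen-bearing groups arrive together, and a 3-methoxyphenyl or 3-propoxyphenyl group at this place would separate them. Also open, going by these compounds, is how far the number moves with a different kind of group here, such as an amine or a carboxylic acid on the phenyl ring.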